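A Chloro Group Added Where No Number Was Found

The source may report more compounds than this note shows. Statements on the series, on what has been measured and on what is new or still open speak of the compounds shown alone.

Two compounds of a shared sulfonamide series have been examined in a functional assay on SNB-75 cells (Homo sapiens) for inhibition; on this read-out higher numbers stand for weaker inhibition of growth and lower numbers for stronger inhibition of growth. Compound 1, `Cc1cc(S(=O)(=O)Nc2nc3ccccc3c(=O)n2N)c(S)cc1Cl`, gives 13300 nM in this assay. Compound 2, `Cc1cc(S(=O)(=O)Nc2nc3cc(-c4ccccc4)sc3c(=O)n2Cc2ccccc2)c(S)cc1Cl`, carries a different fused core bearing a phenyl group and a benzyl group. In this assay compound 2 reaches only the limit of > 100000 nM, so no number is known for it. Among the two values shown, compound 2 thus stands at the limit of > 100000 nM in this assay, at which 1 of the 2 values shown sits.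

Compound 3, `Cc1cc(S(=O)(=O)Nc2nc3cc(-c4ccc(Cl)cc4)sc3c(=O)n2Cc2ccccc2)c(S)cc1Cl`, differs from compound 2 in one place: chloro in place of hydrogen on an aromatic carbon. Among the measured compounds shown here, no measured pair in this set shows that change by itself, so its effect cannot be read from the data. Because compound 2 sits at > 100000 nM, the step from compound 2 to compound 3 is expected to be no larger than the scatter, a step that the limit leaves unreadable from compound 2 to compound 3, in no settled direction. Compound 3 is therefore estimated to give 150000 nM in this assay, within a range from 50000 nM to 500000 nM, and a further limit rather than a number is the most likely report.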

Compound 3, concentration for 50% growth inhibition: > 100000 nM
Compound 3: no number, only a limit; the forecaster's own chance of this, stated with the estimate: 75%; the middle value lies beyond the limit too.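

In this assay compound 3 gives > 100000 nM as a limit and not a number. Compound 2 also stands at a limit, so no step from phenyl to 4-chlorophenyl can be read between compound 2 and compound 3: the limit of > 100000 nM in this assay, at which 2 of the 3 values shown sit.

The compounds shown leave open whether chloro in place of hydrogen on this aromatic carbon changes growth inhibition at all.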